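A shorter side chain on the shared core

The source may hold more compounds than are shown below. What is called first, only, known or untested is meant among the compounds shown, and "the series" means these compounds.

Values so far in a functional assay on HeLa cells (Homo sapiens) for cytotoxicity, read by MTT assay (a lower number here means a stronger inhibitor, a higher number a weaker inhibitor), are these:
Compound 1 `CCC(O)CO[C@H](CC=C(C)C)C1=CC(=O)c2c(O)ccc(O)c2C1=O` gives 28700 nM here
Compound 2 `CC(C)=CC[C@@H](OCC(C)O)C1=CC(=O)c2c(O)ccc(O)c2C1=O` gives 24700 nM here
Compound 3 `CC[C@@](C)(O)CC(=O)O[C@H](CC=C(C)C)C1=CC(=O)c2c(O)ccc(O)c2C1=O` gives 17900 nM here

Compound 3, at 17900 nM in this assay, lies within the usual scatter of both compound 1 and compound 2. Compound 4 `CC(C)=CC[C@@H](OCCO)C1=CC(=O)c2c(O)ccc(O)c2C1=O` has not yet been measured, and its difference from compound 3 is 2-hydroxyethyl in place of (2-hydroxy-2-methylbutyl)carbonyl on an oxygen on a saturated carbon in that one place. For the measured compounds named here, three measured steps bear on this change. The step of a 1.4-fold lower number from compound 2 to compound 3 (0.14 log units; within the scatter) and the step of a 1.6-fold lower number from compound 1 to compound 3 (0.21 log units; within the scatter) each bring in the (2-hydroxy-2-methylbutyl)carbonyl that compound 4 lacks, and both stay within the scatter. The step of a 1.2-fold lower number from compound 1 to compound 2 (0.07 log units; within the scatter) on the saturated chain also stays within it. No step beyond the scatter is therefore expected in this assay for this change. The expected step is a 1.4-fold higher number from compound 3 to compound 4 (0.15 log units; within the scatter) and it remains within the scatter. Compound 4 is estimated at 25000 nM with an expected range of 13000 nM to 45000 nM for this read-out.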

Compound 4, half-maximal inhibitory concentration: 18600 nM
The estimate for compound 4 lay 1.3-fold (0.13 log units) above the measured number, within the range that was stated.
By their numbers in this assay, from the lowest: compounds 3, 4, 2 and 1 (each within the scatter of the next).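

In this assay, 2-hydroxyethyl on an oxygen on a saturated carbon, with 3 heavy atoms, reads like the (2-hydroxy-2-methylbutyl)carbonyl with 8, at a 1.0-fold higher number from compound 3 to compound 4 (0.02 log units; within the scatter), so neither the carbonyl nor the larger group's extra atoms register at this position in this series. Trimming the ether side chain down to its hydroxyethyl form also stays flat, with hydrogen in place of methyl giving a 1.3-fold lower number from compound 2 to compound 4 (0.12 log units; within the scatter) and hydrogen in place of ethyl giving a 1.5-fold lower number from compound 1 to compound 4 (0.19 log units; within the scatter). Nothing available on these compounds accounts for this flat reading.

Every side chain shown still carries a hydroxyl, so it remains open whether a plain ethyl chain, an amine or a carboxylic acid at this position would move the number beyond the scatter. A much longer chain or a ring on the same oxygen is equally untested by these compounds.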